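The compounds below may be only part of what the source reports. "The series", "measured", "known", "first", "only" and "open" are said of these compounds alone.

In an ADME assay on Akata cells (Homo sapiens) for cytotoxicity, with a stated time of 7 days (on this read-out lower numbers stand for higher toxicity in this test and higher numbers for lower toxicity in this test), compound 2 (`CC(C)CNc1nc(N)nc2c1ncn2/C=C1/CC1(CO)CO`) stands at > 24000 nM as a limit of the assay and not a number. Compound 1 (`CCOc1nc(N)nc2c1ncn2/C=C1/CC1(CO)CO`) in this assay likewise gives only a limit at > 20000 nM and no number. Compound 3 (`CCCCCOc1nc(N)nc2c1ncn2/C=C1/CC1(CO)CO`) carries pentyloxy in place of isobutylamino on an aromatic carbon. Within the data shown here, the only measured step bearing on this change is a step that the two limits leave unreadable from compound 1 to compound 2 and it offers no size to carry over, so no step beyond the scatter is expected in this assay. The estimated change is a number no higher from compound 2 to compound 3 (the limit leaves the size open) and stays within the scatter. Compound 3 is expected at 24000 nM with an estimated range from 10000 nM to 55000 nM.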

Compound 3, half-maximal cytotoxic concentration: > 20000 nM
Compound 3 was reported as a limit; the forecaster's own chance of this, stated with the estimate: 65%; the middle value lies beyond the limit too.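

Among these compounds, compound 1, compound 2 and compound 3 all give only limits and not numbers in this assay, so no step among them can be read. The compounds shown leave open whether any of these changes alters toxicity to these cells.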